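Replacing piperazin-1-yl with dimethylamino: what to expect

The compounds below may be only part of what the source reports. "The series", "measured", "known", "first", "only" and "open" are said of these compounds alone.

Of the compounds shown here, three that share one core have been tested in a functional assay on A549 cells (Homo sapiens) for cytotoxicity, read by MTT assay, with a stated time of 72 h; on this read-out lower numbers stand for stronger inhibition and higher numbers for weaker inhibition. Compound 1 `O=C1c2c[n+]([O-])c3ccccc3c2C(=O)c2c1c1ccccc1n2CCCCn1ccnc1` gives 170 nM. Compound 2 `O=C1c2c[n+]([O-])c3ccccc3c2C(=O)c2c1c1ccccc1n2CCCCN1CCNCC1` gives 540 nM. Compound 3 `CC1(C)OC[C@@H](Cn2cc(Cn3c4c(c5ccccc53)C(=O)c3c[n+]([O-])c5ccccc5c3C4=O)nn2)O1` gives 4700 nM. Compound 2 therefore holds the middle place among the three numbers, closest to compound 1 and furthest from compound 3.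

Compound 4 `CN(C)CCCCn1c2c(c3ccccc31)C(=O)c1c[n+]([O-])c3ccccc3c1C2=O` has not been measured yet. It differs from compound 2 in one place: dimethylamino in place of piperazin-1-yl on a saturated chain carbon, four bonds along the chain from an aromatic nitrogen. In words, dimethylamino stands in place of piperazin-1-yl on a saturated chain carbon, four bonds along the chain from an aromatic nitrogen.

Within the data shown here, only one measured step touches this same place: a 3.2-fold higher number from compound 1 to compound 2 (0.50 log units; beyond the scatter), where piperazin-1-yl replaced 1H-imidazol-1-yl. That step is modest, though beyond the usual scatter of repeated measurements. It is a single example involving a different group, so it suggests a plausible size but no direction for the new swap. A step no larger than that one is expected, quite possibly none beyond the scatter, with no firm direction. The estimate amounts to an expected change of a 1.2-fold lower number from compound 2 to compound 4 (0.08 log units; within the scatter). In this assay the estimated value for compound 4 is 450 nM, with an expected range of 150 nM to 1400 nM.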

Compound 4, half-maximal inhibitory concentration: 310 nM
The estimate for compound 4 lay 1.5-fold (0.16 log units) above the measured number; measured number inside the range.
By their numbers in this assay, from the lowest: compounds 1, 4 and 2 (each within the scatter of the next, the first and the last beyond it); then compound 3.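

In this assay, swapping the ring of piperazin-1-yl for the open dimethylamino group at this place on the chain gives a 1.7-fold lower number from compound 2 to compound 4 (0.24 log units; within the scatter), so this pair shows that losing the ring, and with it the hydrogen-bond donor counted for piperazin-1-yl, need not move the number beyond normal assay noise. Compared with the imidazole-bearing compound, the same place gives a 1.8-fold higher number from compound 1 to compound 4 (0.26 log units; within the scatter), which is also too small to separate the two compounds, so dimethylamino cannot be ranked against either 1H-imidazol-1-yl or piperazin-1-yl, even though those two groups are themselves separated by a real step. No measurement of any other kind is available to account for these numbers.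

Still open, from the compounds shown here alone, is how a morpholin-4-yl group or a carboxylic acid would behave at the end of this chain, and whether a larger open amine such as diethylamino would stay as close to these three compounds as dimethylamino does. A shorter or longer chain carrying the same dimethylamino group is also open, since all three of these compounds share one chain length.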